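Acetyl in place of methyl on an aromatic nitrogen

The compounds below may be only part of what the source reports. "The series", "measured", "known", "first", "only" and "open" are said of these compounds alone.

Of the compounds shown here, three on a shared core have been measured in a functional assay on MV4-11 cells (Homo sapiens) for antiproliferative activity, with a stated time of 6 days, tested at 6.25 uM; a higher number here means a stronger effect of the compound at the concentration tested, a lower number a weaker effect. Compound 1 `CNC(=O)N1CCCc2ccc(NC(=O)c3ccc(-c4ccccc4)cc3)cc21` gives 74.3%. Compound 2 `CNC(=O)N1CCCc2ccc(NC(=O)c3ccc(-c4ccn(C)n4)cc3)cc21` gives 97%, and compound 3 `CNC(=O)N1CCCc2ccc(NC(=O)c3cccc(-c4cn[nH]c4)c3)cc21` gives 77.7%. For the measured compounds named here, on these numbers compound 2 stands highest: it lies above compound 3 beyond the scatter, and the one step measured between compounds that differ in one place, a number 22.7 percentage points higher from compound 1 to compound 2 (beyond the scatter), came with 1-methyl-1H-pyrazol-3-yl in place of phenyl on an aromatic carbon.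

Compound 4 `CNC(=O)N1CCCc2ccc(NC(=O)c3ccc(-c4ccn(C(C)=O)n4)cc3)cc21` is not yet measured. Its change from compound 2 is acetyl in place of methyl on an aromatic nitrogen. Going by the values given here, no measured step touches this place: the step from compound 1 to compound 2 changed the group on an aromatic carbon, and compound 3 differs from the others in more than one place, so nothing measured bears directly on acetyl in place of methyl on an aromatic nitrogen. With compound 2 already at 97% in this assay, little room remains upward, and the expected step is therefore a number 12 percentage points lower from compound 2 to compound 4 (beyond the scatter), with the uncertainty lying mostly on the downward side. Compound 4 is accordingly estimated at 85%, within a range from 55% to 100%.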

Compound 4, a percentage reported as inhibition, at one concentration (the size of the read-out at that concentration, not a potency): 91.4%
The estimate for compound 4 lay 6.4 percentage points below the measured number, within the range that was stated.
By their numbers in this assay, from the lowest: compounds 1 and 3 (each within the scatter of the next); then compounds 4 and 2 (each within the scatter of the next).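

In this assay, the nitrogen of the five-membered ring proves open to a larger group: with acetyl in place of methyl there, the step is a number 5.6 percentage points lower from compound 2 to compound 4 (within the scatter), so the two compounds cannot be told apart at the concentration tested. The gain over the phenyl compound also survives this change, with a number 22.7 percentage points higher from compound 1 to compound 2 (beyond the scatter) for the methyl-bearing ring and a number 17.1 percentage points higher from compound 1 to compound 4 (beyond the scatter) for the acetyl-bearing one, so in these three compounds the result does not depend on keeping methyl on that nitrogen. No evidence is available to explain why the read-out stays within the scatter when acetyl enters, with its added carbonyl and hydrogen-bond acceptor.

From the compounds shown here alone, whether other groups on that nitrogen, such as a bare hydrogen, a longer chain like propyl, or a methylsulfonyl group, would keep the read-out in the same range remains open. Also open, going by these compounds, is whether compound 2 and compound 4 would separate in potency, since a single concentration gives the size of the effect and not a potency.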